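A few compounds are considered here, and "the series" means these few. Any claim that something is new, unique, unknown or untested is made for them only; others in the source may bear on it.

Measured so far in an assay on isolated protein for inhibition of lactase/phlorizin hydrolase (Rattus norvegicus), read by colorimetric assay; on this read-out higher numbers stand for weaker inhibition and lower numbers for stronger inhibition:

compound 1 `Cc1ccc(S(=O)(=O)Nc2ccc3c(c2)C(=O)N(CCCCBr)C3=O)cc1` — > 200000 nM
compound 2 `Cc1ccc(S(=O)(=O)Nc2ccc3c(c2)C(=O)N(C)C3=O)cc1` — > 200000 nM
compound 3 `Cc1ccc(S(=O)(=O)Nc2ccc3c(c2)C(=O)N(Cc2ccccc2F)C3=O)cc1` — 180000 nM

Compound 2 stands at the top of the shown range: its value in this assay is a limit of the assay, not a number. Two of the three values sit at that same limit (the limit of > 200000 nM in this assay, at which 2 of the 3 values shown sit). Among the compounds with values here, compound 3 is the one compound with a measured number, and its number is barely inside the measurable range.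

The steps among the measured compounds are small or unreadable. From compound 1 to compound 2 the change is a step that the two limits leave unreadable from compound 1 to compound 2. From compound 1 to compound 3 it is an at least 1.1-fold lower number from compound 1 to compound 3 (0.04 log units; that floor lies within the scatter), and from compound 2 to compound 3 it is an at least 1.1-fold lower number from compound 2 to compound 3 (0.04 log units; that floor lies within the scatter); both of those floors lie within the scatter.

Compound 4 `Cc1ccc(S(=O)(=O)Nc2ccc3c(c2)C(=O)N(CCNc2ccccc2)C3=O)cc1` differs from compound 2 by anilinomethyl in place of hydrogen on a saturated chain carbon bound to an amide-type nitrogen in a ring. Within the data shown here, the one step that bears on this change is the one from compound 2 to compound 3, which was an at least 1.1-fold lower number from compound 2 to compound 3 (0.04 log units; that floor lies within the scatter) and therefore says nothing beyond the scatter. No shift beyond the scatter is expected for compound 4 either, and a further limit is the likelier outcome. For compound 4 in this assay the estimate is 200000 nM, within 100000 nM to 400000 nM. The step from compound 2 to compound 4 is thus expected to be a number no higher from compound 2 to compound 4 (the limit leaves the size open).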

Compound 4, half-maximal inhibitory concentration: 177000 nM
Compound 4: the middle estimate sits 1.1-fold (0.05 log units) above what was measured; measured number inside the range.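

In this assay, anilinomethyl on a saturated chain carbon bound to an amide-type nitrogen in a ring gives compound 4 a measured number, but the change from hydrogen reads only as an at least 1.1-fold lower number from compound 2 to compound 4 (0.05 log units; that floor lies within the scatter), and the change from 2-bromoethyl to anilino reads as an at least 1.1-fold lower number from compound 1 to compound 4 (0.05 log units; that floor lies within the scatter). Set against 2-fluorophenyl, the same group gives a 1.0-fold lower number from compound 3 to compound 4 (0.01 log units; within the scatter), so two different groups, each carrying an aromatic ring, cannot be told apart at this position. Neither compound 3 nor compound 4 shows a step beyond the scatter from the two compounds without an aromatic ring in this group, and those comparisons rest on a limit rather than on numbers: the limit of > 200000 nM in this assay, at which 2 of the 4 values shown sit.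

On these data alone, what a carboxylic acid, a primary amine or a longer chain ending in a phenyl ring would do at this position in this assay remains open. Also open, as far as these compounds go, is whether any change elsewhere on the shared core could bring a step beyond the scatter, which would give this position a more readable starting point.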